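The compounds below may be only part of what the source reports. "The series", "measured", "known", "first", "only" and "open" are said of these compounds alone.

Measured in a functional assay on A549 cells (Homo sapiens) for antiproliferative activity, read by MTT assay, with a stated time of 72 h; on this read-out lower numbers stand for stronger inhibition and higher numbers for weaker inhibition:
- Compound 1 `COc1ccc(N2C(=O)COc3ccc(-c4cnc(Cl)c(NS(=O)(=O)c5ccc(F)cc5)c4)cc32)cc1`: 30400 nM
- Compound 2 `COc1cccc(N2C(=O)COc3ccc(-c4cccc(NS(=O)(=O)c5ccc(F)cc5)c4)cc32)c1`: > 40000 nM, a limit
- Compound 3 `COc1cccc(N2C(=O)COc3ccc(-c4ccc(O)cc4)cc32)c1`: > 40000 nM, a limit

Compound 2 stands at the limit of > 40000 nM in this assay, at which 2 of the 3 values shown sit, so it has a limit and no exact number. Compound 4 `O=C1COc2ccc(-c3cccc(NS(=O)(=O)c4ccc(F)cc4)c3)cc2N1c1ccc(F)cc1` differs from it by 4-fluorophenyl in place of 3-methoxyphenyl on an amide-type nitrogen in a ring. Among the measured compounds shown here, no measured pair shows this swap, so the expectation rests on the overall picture. For the measured compounds named here, the only exact number belongs to compound 1, at 30400 nM, and it shows weak activity. In this assay, no step beyond the usual scatter is expected, in either direction. The estimated change is a number no higher from compound 2 to compound 4 (the limit leaves the size open). Compound 4 is expected at 40000 nM, within an estimated range of 20000 nM to 80000 nM.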

Compound 4, half-maximal inhibitory concentration: > 40000 nM
Compound 4 ended at the assay's limit; the forecaster's own chance of this, stated with the estimate: 60%; the middle value sits exactly at the limit.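

Among the compounds shown here, compound 2 and compound 4 both end at a limit rather than a number, so no step between them can be read: the limit of > 40000 nM in this assay, at which 3 of the 4 values shown sit.
The compounds shown leave open whether 4-fluorophenyl in place of 3-methoxyphenyl on an amide-type nitrogen in a ring changes the activity at all.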